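Sulfonyl aryl variation in a pyridopyrimidinone series

This account rests on a few compounds, and the source may have more. Where it says the series, first, only, none or still open, it means among the compounds named here.

Of the compounds shown here, two of the shared core have been measured in a functional assay on K562 cells (Homo sapiens) for inhibition, read by trypan blue exclusion, with a stated time of 72 h; a lower number here means a stronger inhibitor, a higher number a weaker inhibitor. Compound 1 `Cn1c(=O)c(S(=O)(=O)c2ccc(C(=O)O)cc2)cc2cnc(Nc3ccc4[nH]ccc4c3)nc21` carries a 4-carboxyphenyl on the sulfonyl sulfur, and in this assay compound 1 gives 5000 nM. Compound 2 `Cn1c(=O)c(S(=O)(=O)c2ccc(Cl)cc2Cl)cc2cnc(Nc3ccc4[nH]ccc4c3)nc21` carries a 2,4-dichlorophenyl at the same place, and in this assay compound 2 gives 1000 nM. Going by the values given here, compound 2 thus stands with the lowest of the two numbers, its only neighbour being compound 1, which it beats by a 5.0-fold lower number from compound 1 to compound 2 (0.70 log units; beyond the scatter).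

Compound 3 `Cn1c(=O)c(S(=O)(=O)c2ccc(F)cc2N)cc2cnc(Nc3ccc4[nH]ccc4c3)nc21` is not yet measured. It differs from compound 2 as follows: 2-amino-4-fluorophenyl in place of 2,4-dichlorophenyl on a sulfonyl sulfur.

Among the compounds with values here, only the step from compound 1 to compound 2 touches this place on the sulfonyl sulfur, and it was modest in size, a 5.0-fold lower number from compound 1 to compound 2 (0.70 log units; beyond the scatter). Within the data shown here, no step combines an amino with a fluorine on this ring, so the direction is open; the one precedent says that exchanging the aryl here moves the number modestly rather than greatly. Compound 3 is therefore expected to land near compound 2 or somewhat higher, an estimated 2.0-fold higher number from compound 2 to compound 3 (0.30 log units; within the scatter). The estimate for compound 3 is 2000 nM, within a range of 600 nM to 7000 nM.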

Compound 3, half-maximal inhibitory concentration: 2000 nM
Estimate against measurement, compound 3: no gap at the digits printed; the measured number falls inside the stated range.
By their numbers in this assay, from the lowest: compounds 2 and 3 (each within the scatter of the next); then compound 1.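

In this assay the exchange of 2,4-dichlorophenyl for 2-amino-4-fluorophenyl on the sulfonyl sulfur gives a 2.0-fold higher number from compound 2 to compound 3 (0.30 log units; within the scatter) and so does not separate these two aryl groups, even though the entering group counts a hydrogen-bond donor and a hydrogen-bond acceptor that the leaving group lacks. The other new step, a 2.5-fold lower number from compound 1 to compound 3 (0.40 log units; beyond the scatter) for the same group in place of 4-carboxyphenyl, shows that compound 1 stands apart from both compound 2 and compound 3, which makes 4-carboxyphenyl the only one of the three aryl groups with steps beyond the scatter to both others. No evidence is available on what lies behind these numbers.

Open, going by these compounds, is how a phenyl with no substituent, or one bearing an amino group or a fluorine alone, would read in this assay so the separate share of each group in compound 3 stays unassigned. Also open, on these data alone, is whether a methyl ester or a primary amide in place of the carboxylic acid of compound 1 would close the gap to compound 2 and compound 3, and whether an alkyl chain on the sulfonyl sulfur would be accepted as the aryl groups are.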